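The source may report more compounds than this note shows. Statements on the series, on what has been measured and on what is new or still open speak of the compounds shown alone.

Among the measured compounds shown here, in a functional assay on HepG2 cells (Homo sapiens) for inhibition, read by MTT assay, with a stated time of 72 h (on this read-out higher numbers stand for weaker inhibition and lower numbers for stronger inhibition), compound 2 `CCSc1nc(Nc2cccc(OC)c2)c2ccncc2n1` gives 10700 nM, the only plain number obtained so far in this small set. Compound 1 `C#CCSc1nc(Nc2ccc(OC)cc2)c2ccncc2n1` reaches only the limit of the assay, > 80000 nM, so no number is known for it. Compound 3 `COc1cccc(Nc2nc(SCC3CCCCC3)nc3cnccc23)c1` has not yet been measured; it differs from compound 2 by cyclohexyl in place of methyl on a saturated chain carbon bound to a sulfur, a change on a saturated chain carbon bound to a sulfur. For the measured compounds named here, with no measured step of the same kind to lean on, the change is expected to shift the value only modestly, as the step of a 1.3-fold lower number from compound 2 to compound 3 (0.13 log units; within the scatter) expresses. Compound 3 is therefore estimated at 8000 nM, with a plausible range from 2000 nM to 40000 nM.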

Compound 3, half-maximal inhibitory concentration: 32800 nM
The estimate for compound 3 lay 4.1-fold (0.61 log units) below the measured number, and the stated range covers the measured number.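

In this assay, cyclohexyl in place of methyl on a saturated chain carbon bound to a sulfur brings a 3.1-fold higher number from compound 2 to compound 3 (0.49 log units; beyond the scatter), so inhibition weakens. This first readable step shows that the group at this position can change the result, although compound 3 still gives a plain number. Nothing measured here explains the step.

A single step cannot show a trend. As far as these compounds go, it remains open whether a propyl chain, a phenyl ring or an amine at this position would also weaken inhibition.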